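The compounds below may be only part of what the source reports. "The series", "measured", "known", "first", "only" and "open" are said of these compounds alone.

The shared core of these four esters was examined in a functional assay on MCF7 cells (Homo sapiens) for cytotoxicity, read by MTT assay, with a stated time of 48 h; a lower number here means a stronger inhibitor, a higher number a weaker inhibitor. Compound 1, with the structure `CC(C)c1cccc(OC(=O)c2cn(-c3ccccc3)nc2-c2cccnc2)c1`, gave a half-maximal inhibitory concentration of 75500 nM in this assay. Compound 2, with the structure `CC(C)(C)c1ccc(OC(=O)c2cn(-c3ccccc3)nc2-c2cccnc2)cc1`, differs from compound 1 by a single exchange, (4-(tert-butyl)phenyl in place of 3-isopropylphenyl on an oxygen next to a carbonyl group). Compound 2 reached only the limit of this assay, reported as > 100000 nM. The step of an at least 1.3-fold higher number from compound 1 to compound 2 (0.12 log units; that floor lies within the scatter) therefore runs from a measured number to a limit, and the floor of that step lies within the usual scatter, so its true size is not known; what is known is that it ends at the limit of > 100000 nM in this assay, at which 1 of the 3 values shown sits.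

Compound 3, with the structure `CC(C)c1cccc(OC(=O)c2cn(-c3ccccc3)nc2-c2ccncc2)c1`, keeps the same atoms as compound 1 joined differently, the difference being (pyridin-4-yl in place of pyridin-3-yl on an aromatic carbon). In this assay, within the data shown here, compound 3 gave no usable number, the entry reading "nd(insoluble)" (no result reported), so no step from compound 1 to compound 3 can be sized.

Compound 4, with the structure `CC(C)(C)c1ccc(OC(=O)c2cn(-c3ccccc3)nc2-c2ccncc2)cc1`, has not yet been measured. It stands to compound 3 as compound 2 stands to compound 1, the difference being (4-(tert-butyl)phenyl in place of 3-isopropylphenyl on an oxygen next to a carbonyl group), the same change made on the same place. Among the measured compounds shown here, since compound 3 gave no number, the step from compound 3 to compound 4 cannot be sized beside the earlier one; the only guide is that the same change in compound 2 ended at the limit. For compound 4 the expected value in this assay is 100000 nM, estimated to lie between 40000 nM and 300000 nM, with a high chance that only a limit is reported.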

Compound 4, half-maximal inhibitory concentration: 32300 nM
Compound 4: the middle estimate sits 3.1-fold (0.49 log units) above what was measured; the whole stated range lies above it.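

In this assay the exchange of pyridin-4-yl for pyridin-3-yl on an aromatic carbon, made on the 4-(tert-butyl)phenyl ester, gives an at least 3.0-fold lower number from compound 2 to compound 4 (0.49 log units; beyond the scatter). That size is only a floor because compound 2 stands at a limit of the assay, not at a measured number: the limit of > 100000 nM in this assay, at which 1 of the 4 values shown sits. The steps from compound 1 to compound 3 and from compound 3 to compound 4 cannot be read, as compound 3 gave no number, so the change is seen on the 4-(tert-butyl)phenyl ester alone and nothing shows whether it would carry over to the 3-isopropylphenyl ester.

The compounds shown leave open how large the step from compound 2 to compound 4 really is, and whether the lower number of compound 4 would hold with a pyridin-2-yl group in place of pyridin-4-yl. They also leave open what an amine or a carboxylic acid on the phenyl ring of the ester would do in this assay, and whether an amide in place of the ester link would keep a measurable number there.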